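This account rests on a few compounds, and the source may have more. Where it says the series, first, only, none or still open, it means among the compounds named here.

Compound 1 `Fc1ccc(-c2cn3ccnc3c(-c3ccc4ncn(C5CCCCC5)c4c3)n2)cc1` is tested in a functional assay on HCT-116 cells (Homo sapiens) for inhibition, read by sulforhodamine B assay, with a stated time of 48 h, tested at 10 uM (on this read-out higher numbers stand for more inhibition at the one concentration tested (going by the name of the read-out) and lower numbers for less inhibition), where compound 1 gives 18%. Its companion compound 2 `Brc1ccc(-c2cn3ccnc3c(-c3ccc4ncn(C5CCCCC5)c4c3)n2)cc1` gives 31.2% in the same assay, so compound 1 stands lowest of the two numbers, with the step of a number 13.2 percentage points higher from compound 1 to compound 2 (beyond the scatter) separating them. Compound 3 `COc1ccccc1-c1cn2ccnc2c(-c2ccc3ncn(C4CCCCC4)c3c2)n1` carries a change from compound 1 that the data describe as 2-methoxyphenyl in place of 4-fluorophenyl on an aromatic carbon. Within the data shown here, the one measured step, bromo in place of fluoro, concerns a different group at the same aromatic carbon and bears only loosely on this change; no measured pair shows a methoxy group entering or a fluorine leaving. The modest gain from fluoro to bromo suggests that replacing the 4-fluorophenyl need not lower the inhibition, but gives no firm direction. Compound 3 is therefore expected to sit within the scatter of compound 1 or a little higher, with an estimated step of a number 4 percentage points higher from compound 1 to compound 3 (within the scatter). The estimated inhibition of compound 3 is 22%, expected between 8% and 40%.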

Compound 3, a percentage reported as inhibition, at one concentration (the size of the read-out at that concentration, not a potency): 28.3%
Compound 3: middle estimate off by 6.3 percentage points, on the low side, within the range that was stated.
By their numbers in this assay, from the lowest: compound 1; then compounds 3 and 2 (each within the scatter of the next).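

The change from 4-fluorophenyl to 2-methoxyphenyl at this aromatic carbon gives a number 10.3 percentage points higher from compound 1 to compound 3 (beyond the scatter), so a phenyl group with a different substituent, placed differently on that ring, keeps the inhibition above that of compound 1. The further comparison gives a number 2.9 percentage points lower from compound 2 to compound 3 (within the scatter), which means that 2-methoxyphenyl and 4-bromophenyl cannot be told apart here, and that two quite different replacements of the 4-fluorophenyl both leave compound 1 lowest of the three. Nothing available explains this result.

The compounds shown do not separate the effect of the methoxy group itself from that of its place on the phenyl ring, as 4-methoxyphenyl does not appear among them. From the compounds shown here alone, how an amine or a carboxylic acid on that phenyl ring would read also remains open.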